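Swapping the oxazole for a methoxyazetidine on the amide

The source may hold more compounds than are shown below. What is called first, only, known or untested is meant among the compounds shown, and "the series" means these compounds.

Of the compounds shown here, three sharing one core have been measured in an ADME assay on LLC-PK1 cells (Sus scrofa) for permeability; a higher number here means that the compound crosses the layer faster, a lower number that the compound crosses the layer more slowly. Compound 1 `CCn1c(-c2cnc(C)nc2)nc2c(O[C@H]3CCN(C(=O)C4CC4)C3)ncnc21` gives 28 10^-6 cm/s, compound 2 `CCC(=O)N1CC[C@H](Oc2ncnc3c2nc(-c2cnc(C)nc2)n3CC)C1` gives 21 10^-6 cm/s, and compound 3 `CCn1c(-c2ccc(C(F)(F)F)nc2)nc2c(O[C@H]3CCN(C(=O)c4cocn4)C3)ncnc21` gives 29 10^-6 cm/s. All three numbers lie within the usual scatter of one another, so compound 3 stands level with compounds 1 and 2 rather than apart from them.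

Compound 4 `CCn1c(-c2ccc(C(F)(F)F)nc2)nc2c(O[C@H]3CCN(C(=O)N4CC(OC)C4)C3)ncnc21` differs from compound 3 in one place: 3-methoxyazetidin-1-yl in place of 1,3-oxazol-4-yl on a carbonyl carbon. Among the measured compounds shown here, the only measured step that touches the same carbonyl carbon is a 1.3-fold lower number from compound 1 to compound 2 (0.12 log units; within the scatter), and it stayed within the scatter. For the measured compounds named here, no measured pair shows an exchange of a ring like the one entering here, so the evidence is thin; what it does show is that altering the group on that carbonyl carbon left this assay unchanged. The step of a 1.2-fold lower number from compound 3 to compound 4 (0.08 log units; within the scatter) is therefore expected to stay within the scatter, with no direction favoured. Compound 4 is estimated at 24 10^-6 cm/s, within a range from 12 10^-6 cm/s to 45 10^-6 cm/s.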

Compound 4, apparent permeability: 33 10^-6 cm/s
Compound 4: middle estimate off by 1.4-fold (0.14 log units), on the low side; low and high end bracket the measured number.
By their numbers in this assay, from the lowest: compounds 2, 1, 3 and 4 (each within the scatter of the next).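

The step of a 1.1-fold higher number from compound 3 to compound 4 (0.06 log units; within the scatter) extends what was seen at this carbonyl carbon in this assay. Among the compounds shown here, until now, the only step read there was the small exchange of cyclopropyl for ethyl, whereas this one replaces a five-membered aromatic ring with a four-membered non-aromatic ring carrying a methoxy group, and the read-out still stays within the scatter. Nothing available here explains why so large a change in structure leaves the number level.

As far as these compounds go, it remains open whether a group with a net charge on this carbonyl carbon, such as an amine or a carboxylic acid, would also leave the number level. From the compounds shown here alone, it is also open whether the exchange of 1,3-oxazol-4-yl for 3-methoxyazetidin-1-yl would read the same on the other compounds' background, such as that of compound 1.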